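The source may hold more compounds than are shown below. What is called first, only, known or untested is meant among the compounds shown, and "the series" means these compounds.

Of the compounds shown here, three have so far been measured in a functional assay on U-251 cells (Homo sapiens) for cytotoxicity, read by sulforhodamine B assay, with a stated time of 48 h; a lower number here means that less compound is tolerated, a higher number that more compound is tolerated. Compound 1 `ClCc1ccccc1Cn1cnc2c(Cl)ncnc21` gives 61700 nM in this assay. Compound 2 `ClCc1ccccc1Cn1cnc2ncnc(Cl)c21` gives 10200 nM. Compound 3 `ClCc1cccc(Cn2cnc3nc(Cl)nc(Cl)c32)c1` gives 5120 nM. Among these three numbers compound 2 stands second highest; its value and that of compound 3 lie within the scatter of each other, so no order between them can be read, whereas compound 1 gives a higher number than compound 2 by a margin beyond the scatter.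

The next compound, compound 4 `ClCc1ccccc1Cn1cnc2nc(Cl)nc(Cl)c21`, has not yet been measured. It differs from compound 2 by a single change, (chloro in place of hydrogen on an aromatic carbon), a chloro in place of hydrogen on an aromatic carbon of the core, between two ring nitrogen atoms. Among the measured compounds shown here, no measured pair shows this change directly. The step is expected to be small because compound 3 gives 5120 nM while carrying the same two chloro groups on its core, a value within the scatter of compound 2; a modest move toward a lower number, or none beyond the scatter, is anticipated. For compound 4 the expected value is 6500 nM, within a range from 2200 nM to 19000 nM. That estimate corresponds to a step of a 1.6-fold lower number from compound 2 to compound 4 (0.20 log units; within the scatter).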

Compound 4, concentration lethal to 50% of the cells: 3630 nM
Estimate against measurement, compound 4: 1.8-fold (0.25 log units) above, within the range that was stated.
By their numbers in this assay, from the lowest: compounds 4, 3 and 2 (each within the scatter of the next, the first and the last beyond it); then compound 1.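

In this assay, among the compounds shown here, a chloro in place of hydrogen on the aromatic carbon between two ring nitrogen atoms gives a 2.8-fold lower number from compound 2 to compound 4 (0.45 log units; beyond the scatter) and provides the first direct reading of this change. The position is therefore not silent: this single added chloro, with the rest of the structure unchanged, shifts the number by a modest step beyond the scatter. Nothing available here accounts for that shift.

The compounds shown carry only hydrogen or chloro at this position, so the effect of an amine, a methoxy group or a methyl group there remains open. The change is also read in this one pair only, which leaves open how large it would be on the core of compound 1.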